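The source may report more compounds than this note shows. Statements on the series, on what has been measured and on what is new or still open speak of the compounds shown alone.

The three measured compounds, compound 1 `Cc1c(/C=N/NC(=O)c2ccncc2)no[n+]1[O-]`, compound 2 `Cc1c(C(=O)N/N=C/c2ccc(N(C)C)cc2)no[n+]1[O-]` and compound 3 `Cc1nc2ccccn2c1C(=O)N/N=C/c1ccc2no[n+]([O-])c2c1`, were all tested in an ADME assay on J774.1 cells (Mus musculus) for cytotoxicity, read by MTT assay, with a stated time of 48 h; a higher number here means a weaker inhibitor, a lower number a stronger inhibitor. For compound 1 the result is not a number but a limit of the assay, > 400000 nM. Compound 2 gives 129000 nM, and compound 3 gives 141000 nM; these two numbers lie within the usual scatter of each other, so no difference between them can be claimed. For the measured compounds named here, compound 2 thus sits alongside the only other real number in the set, while the third result is a limit.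

Compound 4 `Cc1c(C(=O)N/N=C/c2ccc(Br)cc2)no[n+]1[O-]` has not yet been measured. It differs from compound 2 in one place: bromo in place of dimethylamino on an aromatic carbon. Going by the values given here, no measured pair in this set differs by a single change, so there is no measured step of this kind to lean on, and nothing here shows what a bromo group does in place of a dimethylamino group. In this assay the expected step is a 1.2-fold higher number from compound 2 to compound 4 (0.07 log units; within the scatter), not beyond the scatter in either direction. Compound 4 is estimated to give about 150000 nM in this assay, with a plausible range from 60000 nM to 400000 nM.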

Compound 4, half-maximal inhibitory concentration: 162000 nM
The estimate for compound 4 lay 1.1-fold (0.03 log units) below the measured number, and the stated range covers the measured number.
By their numbers in this assay, from the lowest: compounds 2, 3 and 4 (each within the scatter of the next). At a limit, above all of these: compound 1.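

In this assay, for the compounds shown here, this is the first measured comparison in the set between two compounds that differ in only one place: a 1.3-fold higher number from compound 2 to compound 4 (0.10 log units; within the scatter), for bromo in place of dimethylamino on an aromatic carbon para to a large group. The group that leaves has three heavy atoms and one hydrogen-bond acceptor, while the one that enters is a single bromine atom with no acceptor, yet this exchange gives no difference that can be told apart from the scatter of repeated measurements. The step can be read as a real comparison because neither compound 2 nor compound 4 is the compound that stands at a limit rather than a number: the limit of > 400000 nM in this assay, at which 1 of the 4 values shown sits.

Still open, on these data alone, is how this position responds to other kinds of group, such as a carboxylic acid, a primary amine or a longer alkyl chain, any of which could give a step beyond the scatter or none at all. Also open, as far as these compounds go, is whether bromo in place of dimethylamino reads the same way on a different core, such as that of compound 3, since this single pair speaks only for the core shared by compound 2 and compound 4.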